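Replacing the hydroxyphenyl group of compound 1 with a carboxypyridinyl group

The source may hold more compounds than are shown below. What is called first, only, known or untested is meant among the compounds shown, and "the series" means these compounds.

Compound 1 `O=C(CCCCCCc1ccccc1)c1ncc(-c2cccc(O)c2)o1` is the weakest of the three measured compounds in an assay (Rattus norvegicus) for inhibition of Fatty-acid amide hydrolase 1 (Homo sapiens) (a lower number here means a stronger inhibitor, a higher number a weaker inhibitor), where compound 1 gives 50 nM. Two neighbours share its core. Compound 2 `NC(=O)c1cccc(-c2cnc(C(=O)CCCCCCc3ccccc3)o2)c1` gives 6 nM in this assay, and compound 3 `Cc1cccnc1-c1cnc(C(=O)CCCCCCc2ccccc2)o1` gives 15 nM. The step of an 8.3-fold lower number from compound 1 to compound 2 (0.92 log units; beyond the scatter) and the step of a 3.3-fold lower number from compound 1 to compound 3 (0.52 log units; beyond the scatter) both show that exchanging the 3-hydroxyphenyl group for another aryl group lowered the number, while the step of a 2.5-fold higher number from compound 2 to compound 3 (0.40 log units; beyond the scatter) shows that the carbamoyl-bearing ring did better than the methylpyridinyl ring.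

Compound 4 `O=C(CCCCCCc1ccccc1)c1ncc(-c2ncccc2C(=O)O)o1` is not yet measured. It differs from compound 1 as follows: 3-carboxypyridin-2-yl in place of 3-hydroxyphenyl on an aromatic carbon. The change combines a pyridin-2-yl ring, as in compound 3, with a carbonyl-bearing substituent, as in compound 2, though here a carboxy group in place of the carbamoyl. Both measured steps bearing on this position were modest improvements beyond the scatter, so a step of similar size downward is expected, with wider uncertainty because no acid has been measured in this set. The estimated step is a 2.5-fold lower number from compound 1 to compound 4 (0.40 log units; beyond the scatter). Compound 4 is therefore expected to give about 20 nM in this assay, within a range of 5 nM to 100 nM.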

Compound 4, inhibition constant: > 50 nM
Compound 4: only a limit was reported; the forecaster's own chance of this, stated with the estimate: 5%; middle value at least 2.5-fold (0.39 log units) away from the limit.
By their numbers in this assay, from the lowest: compound 2; then compound 3; then compound 1.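

The reading of compound 4 in this assay is a limit of the assay and not a number: the limit of > 50 nM in this assay, at which 1 of the 4 values shown sits. Carboxy in place of methyl on an aromatic carbon gives an at least 3.3-fold higher number from compound 3 to compound 4 (0.52 log units; beyond the scatter), so the pyridin-2-yl ring that gave a lower number than the 3-hydroxyphenyl group when it bore a methyl no longer does so when it bears a carboxy group. Against the carbamoyl-bearing ring the result is an at least 8.3-fold higher number from compound 2 to compound 4 (0.92 log units; beyond the scatter), which shows that a carbonyl-bearing substituent at this position does not by itself bring the low number of compound 2, while the remaining step is a number no lower from compound 1 to compound 4 (the limit leaves the size open), and its size cannot be read.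

On these data alone, how far the true number of compound 4 lies beyond the limit stays open, and with it the full size of both losses. Also open, as far as these compounds go, is whether the loss belongs to the carboxylic acid as such or to its combination with the pyridin-2-yl ring, a question that a methyl ester in place of the carboxy group, or a carboxy group on a plain phenyl ring, would address.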